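Isoquinolin-3-yl in place of phenyl on compound 2

The source may report more compounds than this note shows. Statements on the series, on what has been measured and on what is new or still open speak of the compounds shown alone.

For the measured compounds named here, in a physicochemical assay for solubility, measured as thermodynamic solubility, at pH 7.4 (a higher number here means a more soluble compound, a lower number a less soluble compound), compound 2 `CC(=O)N1CCN(c2nc(NCc3ccccc3)c3c(n2)C(=O)N(C(C)C)C3)CC1` gives 230000 nM, the higher of the two actual numbers so far. Compound 3 `CCOc1ccc([C@@H](CC)Nc2nc(N3CCN(C(C)=O)CC3)nc3c2CN(C(C)C)C3=O)cc1` gives 86000 nM, a gap to compound 2 that lies beyond the scatter. Compound 1 `COCCNc1nc(NC(c2ccccc2)c2ccccc2)c2c(n1)C(=O)N(C(C)C)C2` reads < 1000 nM, which is a limit and not a number.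

Compound 4 `CC(=O)N1CCN(c2nc(NCc3cc4ccccc4cn3)c3c(n2)C(=O)N(C(C)C)C3)CC1` carries isoquinolin-3-yl in place of phenyl on a saturated chain carbon bound to a nitrogen on an aromatic ring. Going by the values given here, no measured pair isolates this change. Among the compounds with values here, the only guide is compound 3, whose group on that nitrogen is also larger than benzyl and which stands at 86000 nM. The step expected in this assay is downward and beyond the scatter: a 3.8-fold lower number from compound 2 to compound 4 (0.58 log units; beyond the scatter). The estimate for compound 4 is 60000 nM, with the expected range running from 15000 nM to 200000 nM.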

Compound 4, solubility: 590000 nM
The estimate for compound 4 lay 9.8-fold (0.99 log units) below the measured number; measured number above the stated range.
By their numbers in this assay, from the lowest: compound 3; then compound 2; then compound 4. At a limit, below all of these: compound 1.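

In this assay, this replacement at the position gives a 2.6-fold higher number from compound 2 to compound 4 (0.41 log units; beyond the scatter). A group of 10 heavy atoms, with a second aromatic ring and one hydrogen-bond acceptor, therefore sits on the saturated chain carbon without any fall in the number. Nothing in the data on hand accounts for the step.

Open, going by these compounds, is whether the added carbon ring or the ring nitrogen of isoquinolin-3-yl carries the step, since both enter together. A naphthyl or a pyridyl group on the same carbon would separate the two.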